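Sulfonamide in Place of Amide on the Ring Amine

The compounds below may be only part of what the source reports. "The series", "measured", "known", "first", "only" and "open" are said of these compounds alone.

Measured compounds:
Compound 1, `CCC(=O)N[C@@H]1CCCc2c1cncc2N1Cc2cc(Cl)ccc2C1=O`: 28 nM
Compound 2, `CCC(=O)N[C@@H]1CCCc2c1cncc2N1C(=O)c2ccc(Cl)cc2[C@@H]1CC`: 12 nM

In an assay on cells for inhibition of cytochrome P450 11B2, mitochondrial (Homo sapiens), read by HTRF (on this read-out higher numbers stand for weaker inhibition and lower numbers for stronger inhibition), compound 1 gives 28 nM, the highest of the two numbers; compound 2 gives 12 nM. Among the compounds with values here, the only measured step, a 2.3-fold lower number from compound 1 to compound 2 (0.37 log units; beyond the scatter), concerns a different site, ethyl in place of hydrogen on a saturated ring carbon, and so says nothing about the amine nitrogen.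

Compound 3, `CS(=O)(=O)N[C@@H]1CCCc2c1cncc2N1Cc2cc(Cl)ccc2C1=O`, differs from compound 1 at that nitrogen: methylsulfonyl in place of propanoyl on an amine nitrogen. Within the data shown here, no measured step bears on this exchange, so the direction is open. Compound 3 is therefore expected near compound 1 in this assay, with an expected step of a 1.6-fold higher number from compound 1 to compound 3 (0.21 log units; within the scatter) and a wide range. The estimate for compound 3 is 45 nM, between 10 nM and 200 nM.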

Compound 3, half-maximal inhibitory concentration: 998 nM
For compound 3 the middle estimate is 22-fold (1.35 log units) below the measured one, outside the stated range (above it).
By their numbers in this assay, from the lowest: compound 2; then compound 1; then compound 3.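

In this assay the exchange on the amine nitrogen brings a 36-fold higher number from compound 1 to compound 3 (1.55 log units; beyond the scatter), so this position does not treat the two groups alike, even though propanoyl and methylsulfonyl have the same number of heavy atoms and neither has a ring or a net charge. This step is much larger than a 2.3-fold lower number from compound 1 to compound 2 (0.37 log units; beyond the scatter), the only earlier one, which lies at a saturated ring carbon. Nothing measured here accounts for the difference.

The compounds shown leave open whether the change follows the sulfonyl unit or the shorter carbon chain, as methylsulfonyl differs from propanoyl in both; acetyl or ethylsulfonyl on the same nitrogen would separate the two. They also leave open whether the ethyl group of compound 2 would have the same effect alongside methylsulfonyl on that nitrogen.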